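A larger amino group on the chain of compound 2

This account rests on a few compounds, and the source may have more. Where it says the series, first, only, none or still open, it means among the compounds named here.

In a functional assay on HeLa cells (Homo sapiens) for antiproliferative activity, read by MTT assay, with a stated time of 48 h (a lower number here means a stronger inhibitor, a higher number a weaker inhibitor), compound 1 `CCCn1c(N)c(-c2nc3ccccc3[nH]2)c2nc(C#N)c(C#N)nc21` gives > 50000 nM as its result, which is a limit of the assay and not a number. Among the compounds with values here, compound 2 `CN(C)CCCn1c(N)c(-c2nc3ccccc3[nH]2)c2nc(C#N)c(C#N)nc21`, with a dimethylamino group on its chain, gives 25900 nM as the only true number so far, so it has no measured neighbour to be ranked against. Within the data shown here, the one measured step is an at least 1.9-fold lower number from compound 1 to compound 2 (0.28 log units; that floor lies within the scatter) and comes from putting dimethylamino in place of hydrogen. Compound 3 `CCN(CC)CCCn1c(N)c(-c2nc3ccccc3[nH]2)c2nc(C#N)c(C#N)nc21` has diethylamino in place of dimethylamino on a saturated chain carbon, three bonds along the chain from an aromatic nitrogen. Among the measured compounds shown here, no measured step exchanges one amino group for another, so the evidence here is thin. For the measured compounds named here, the only guide is an at least 1.9-fold lower number from compound 1 to compound 2 (0.28 log units; that floor lies within the scatter) and that step adds the amino group instead of altering it, so it sets no size for this change. No step beyond the scatter is therefore expected in this assay for this swap. The estimated move is a 1.2-fold lower number from compound 2 to compound 3 (0.07 log units; within the scatter) and it is a small one. Compound 3 is estimated to give 22000 nM with an expected range of 8000 nM to 50000 nM around that figure.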

Compound 3, half-maximal inhibitory concentration: 3150 nM
Compound 3: middle estimate off by 7.0-fold (0.84 log units), on the high side, and the stated range ends above it.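

This position is sensitive to which amino group sits on the chain, not only to whether one is there. Within the data shown here, with the chain and the shared core unchanged, exchanging dimethylamino for diethylamino gives an 8.2-fold lower number from compound 2 to compound 3 (0.91 log units; beyond the scatter) in this assay, the first step that is firmly beyond the scatter. Against the chain with no amino group at all, diethylamino gives an at least 15-fold lower number from compound 1 to compound 3 (1.20 log units; beyond the scatter), and this size is only a floor, because compound 1 stands at a limit of the assay and not at a true number: the limit of > 50000 nM in this assay, at which 1 of the 3 values shown sits.

Among these compounds, with only two amino groups to compare, it remains open whether the number would keep falling with a larger open-chain amine such as dipropylamino, or how a ring amine such as piperidine or morpholine would behave at the same place. The length of the chain is also unresolved, since 3-(diethylamino)propyl is the only diethylamino chain shown, and a shorter 2-(diethylamino)ethyl or a longer butyl chain carrying the same amine could give quite a different result.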